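A Fluorine Swap on a Shared Core

A few compounds are considered here, and "the series" means these few. Any claim that something is new, unique, unknown or untested is made for them only; others in the source may bear on it.

Measured compounds:
- compound 1, `CC(C)n1c(/C=C2/C(=O)Nc3ccccc32)nc2ccccc21`: 39500 nM
- compound 2, `CCn1c(/C=C2/C(=O)Nc3ccccc32)nc2ccccc21`: "not determined" (no result reported)
- compound 3, `Cn1c(/C=C2/C(=O)Nc3ccc([N+](=O)[O-])cc32)nc2ccccc21`: "not determined" (no result reported)

The study rests on three compounds that share one core, yet only one of them carries a number. In a functional assay on MCF7 cells (Homo sapiens) for cytotoxicity, read by MTT assay, with a stated time of 48 h (on this read-out higher numbers stand for weaker inhibition and lower numbers for stronger inhibition), compound 1 gives 39500 nM, a weak result. Compound 2 has no value in this assay, and the same holds for compound 3, so compound 1 is the only number shown, with two further entries that lack a single figure. Among the compounds with values here, no step between two measured compounds can therefore be read off.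

The next compound, compound 4, `CC(C)n1c(/C=C2/C(=O)Nc3ccc(F)cc32)nc2ccccc21`, differs from compound 1 in one place: fluoro in place of hydrogen on an aromatic carbon. Since nothing measured shows what this kind of swap does here, no step beyond the scatter can be expected in either direction.

For compound 4 the expected step in this assay is a 1.3-fold lower number from compound 1 to compound 4 (0.12 log units; within the scatter), essentially none. Compound 4 is therefore estimated at 30000 nM, with a range from 10000 nM to 100000 nM.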

Compound 4, half-maximal inhibitory concentration: 29000 nM
The estimate for compound 4 lay 1.0-fold (0.01 log units) above the measured number; measured number inside the range.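

Within the data shown here, the swap of fluoro for hydrogen gives the first readable step on this core: in this assay it brings a 1.4-fold lower number from compound 1 to compound 4 (0.13 log units; within the scatter), so the two compounds cannot be told apart. At this aromatic carbon, meta to a fused ring and para to a fused ring, a single fluorine atom therefore leaves the read-out without a change beyond the scatter, and this one swap offers no route to a clearly stronger compound. No step to compound 2 or compound 3 can be read, and no measurement here offers an explanation for this result.

Open, on these data alone, is whether a larger group on the same carbon, such as a methoxy group or an amine, would shift the number beyond the scatter. Also open, as far as these compounds go, is whether fluoro on another carbon of this ring would give a different result.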